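The source may hold more compounds than are shown below. What is called first, only, known or untested is meant among the compounds shown, and "the series" means these compounds.

Measured in a functional assay on the whole organism with Mus musculus as the target; a lower number here means that less compound is needed, a higher number that more compound is needed for the effect:
- compound 1 `C[C@@H](NCc1ccc(OCc2ccccc2)cc1)C(N)=O`: 23.8 mg/kg
- compound 2 `CNC(=O)[C@H](CCSC)NCc1ccc(OCc2ccccc2)cc1`: 239 mg/kg

Compound 2 holds the higher of the two numbers, and its gap to compound 1 lies beyond the scatter. Compound 3 `CNC(=O)[C@@H](NCc1ccc(OCc2ccccc2)cc1)C(C)C` has isopropyl in place of 2-(methylsulfanyl)ethyl on a saturated chain carbon bound to an amine nitrogen and a carbonyl carbon. Among the compounds with values here, no measured pair isolates this change, and compounds 1 and 2 differ in more than one place. The expectation therefore rests loosely on compound 1 at 23.8 mg/kg. In this assay, a fall in the number beyond the scatter is expected, with an estimated 3.4-fold lower number from compound 2 to compound 3 (0.53 log units; beyond the scatter). The estimate for compound 3 is 70 mg/kg, with an expected range of 25 mg/kg to 200 mg/kg.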

Compound 3, dose for half-maximal effect: 55.4 mg/kg
The estimate for compound 3 lay 1.3-fold (0.10 log units) above the measured number; low and high end bracket the measured number.
By their numbers in this assay, from the lowest: compound 1; then compound 3; then compound 2.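

In this assay, isopropyl in place of 2-(methylsulfanyl)ethyl on a saturated chain carbon bound to an amine nitrogen and a carbonyl carbon gives a 4.3-fold lower number from compound 2 to compound 3 (0.63 log units; beyond the scatter) and so shows that the number responds to the group at this carbon. Even so, 2-methyl-1-(methylcarbamoyl)propyl in place of 1-carbamoylethyl on an amine nitrogen gives a 2.3-fold higher number from compound 1 to compound 3 (0.37 log units; beyond the scatter) as a remaining gap. Nothing available accounts for either step. Going by these compounds, how a benzyl group would fare at this carbon remains open, as does how much of the gap to compound 1 belongs to the methyl on the amide nitrogen.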